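Moving from a bromophenyl to a trifluoromethylphenyl urea

A few compounds are considered here, and "the series" means these few. Any claim that something is new, unique, unknown or untested is made for them only; others in the source may bear on it.

Measured compounds:
compound 1, `COc1cc(NC(C)CCCNC(=O)NNC(=O)Nc2cccc(F)c2)c2ncccc2c1`, 150 nM
compound 2, `COc1cc(NC(C)CCCNC(=O)NNC(=O)Nc2cc(C(F)(F)F)cc(C(F)(F)F)c2)c2ncccc2c1`, 2400 nM
compound 3, `COc1cc(NC(C)CCCNC(=O)NNC(=O)Nc2ccc(Br)cc2)c2ncccc2c1`, 100 nM

In a functional assay on MCF7 cells (Homo sapiens) for inhibition, read by MTT assay, with a stated time of 72 h (on this read-out lower numbers stand for stronger inhibition and higher numbers for weaker inhibition), compound 3 gives 100 nM, the lowest of the three numbers; compound 1 sits nearest with 150 nM, and compound 2 stands furthest away with 2400 nM. Compound 4, `COc1cc(NC(C)CCCNC(=O)NNC(=O)Nc2cccc(C(F)(F)F)c2)c2ncccc2c1`, has not yet been measured. The change from compound 3 to compound 4 is 3-(trifluoromethyl)phenyl in place of 4-bromophenyl on an amide-type nitrogen. For the measured compounds named here, only one measured step bears on it directly: a 1.5-fold lower number from compound 1 to compound 3 (0.18 log units; within the scatter), which shows that exchanging one halogenated phenyl ring for another at this amide-type nitrogen left the number within the scatter. Compound 2, which also carries trifluoromethyl groups on the phenyl ring, gives a much higher number than compound 1 or compound 3. A single trifluoromethyl is expected to fall between these cases, so a moderate step upward, a 4.0-fold higher number from compound 3 to compound 4 (0.60 log units; beyond the scatter), is expected. Compound 4 is therefore estimated at 400 nM, with a range from 150 nM to 1200 nM.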

Compound 4, half-maximal inhibitory concentration: 190 nM
The estimate for compound 4 lay 2.1-fold (0.32 log units) above the measured number, and the stated range covers the measured number.
By their numbers in this assay, from the lowest: compounds 3, 1 and 4 (each within the scatter of the next); then compound 2.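

In this assay a single 3-(trifluoromethyl)phenyl on the amide-type nitrogen behaves much like the halogenated rings: a 1.9-fold higher number from compound 3 to compound 4 (0.28 log units; within the scatter) and a 1.3-fold higher number from compound 1 to compound 4 (0.10 log units; within the scatter) are both printed as within the scatter, so one trifluoromethyl group does not by itself produce the high number of compound 2. For the compounds shown here, the jump appears only with the second trifluoromethyl group, and a 13-fold lower number from compound 2 to compound 4 (1.10 log units; beyond the scatter) isolates this single change on the ring, which the earlier compounds could not do. Nothing shown here explains the difference between one and two trifluoromethyl groups.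

Going by these compounds, it remains open whether a phenyl ring bearing a nitrile, a methoxy group or a carboxylic acid would stay with compound 1, compound 3 and compound 4. On these data alone, it is also open whether the same picture would hold with a shorter chain on the shared core.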